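The compounds below may be only part of what the source reports. "The series", "measured", "known", "first", "only" and "open" are said of these compounds alone.

Measured so far:
compound 1 `NC(N)=NC(=O)c1nc(Cl)c(NCc2ccc(Cl)cc2)nc1N`: 46%
compound 2 `NC(N)=NC(=O)c1nc(Cl)c(N2CCCC2)nc1N`: 12%
compound 3 `NC(N)=NC(=O)c1nc(Cl)c(N2CCc3ccccc32)nc1N`: 46%

In an assay for inhibition of acid-sensing ion channel 3 (Homo sapiens), read by patch clamp, tested at 1 uM (a lower number here means less inhibition, a higher number more inhibition at the concentration tested (going by the name of the read-out)), compound 2 gives 12%, the lowest of the three numbers. Compound 1 gives 46% and compound 3 gives 46%; each of the two stands above compound 2 by a gap that is beyond the usual scatter, and the two gaps are of the same size. Within the data shown here, no two measured compounds differ in a single place, so there is no measured step on which to scale a single change.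

The next compound is compound 4 `NC(N)=NC(=O)c1nc(Cl)c(Sc2ccccc2)nc1N`. Relative to compound 2 the change is phenylsulfanyl in place of pyrrolidin-1-yl on an aromatic carbon. The leaving group is a five-membered non-aromatic ring, the entering group brings a six-membered aromatic ring of carbon only; donor and acceptor counts are unchanged.

The step of a number 28 percentage points higher from compound 2 to compound 4 (beyond the scatter) is expected to be upward and beyond the scatter. Compound 1 at 46% and compound 3 at 46% stand well above compound 2, whose 12% is the outlier of the set. The expectation for compound 4 rests on those two higher values of the shared core. For compound 4 the expected inhibition is 40%, with a range from 20% to 60%.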

Compound 4, a percentage reported as inhibition, at one concentration (the size of the read-out at that concentration, not a potency): 11%
The estimate for compound 4 lay 29 percentage points above the measured number; measured number outside the range, below it.
By their numbers in this assay, from the lowest: compounds 4 and 2 (each within the scatter of the next); then compounds 1 and 3 (each within the scatter of the next).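

In this assay, replacing pyrrolidin-1-yl with phenylsulfanyl on this aromatic carbon gives a number 1 percentage points lower from compound 2 to compound 4 (within the scatter), so this change, which brings in a six-membered aromatic ring of carbon only, leaves the read-out indistinguishable from that of the pyrrolidine. A ring of this kind at this place is therefore not enough on its own for a number like those of the two compounds that also carry a benzene ring, with compound 1 at 46% and compound 3 at 46%; compound 4 goes against any reading of the series in which the aromatic ring alone sets the read-out. No measurement shown accounts for this result.

The compounds shown leave open whether the sulfur linking atom of compound 4 or the missing chloro group on its ring accounts for the gap to compound 1. A phenylamino group, a phenoxy group or a 4-chlorophenylsulfanyl group on the same aromatic carbon would separate these two features on the shared core.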